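The source may hold more compounds than are shown below. What is called first, only, known or untested is meant among the compounds shown, and "the series" means these compounds.

Compound 1 `O=C(Nc1ccc2nc(NC(=O)C3CCCCC3)sc2c1)c1ccc(Cl)cc1Cl` was tested in a functional assay on WI-38 VA13 cells (Homo sapiens) for cytotoxicity; on this read-out higher numbers stand for an effect only at larger amounts of compound and lower numbers for an effect already at smaller amounts. In this assay compound 1 gives > 4 ug/mL, which is a limit of the assay and not a number (the limit of > 4 ug/mL in this assay, at which 1 of the 3 values shown sits). Compound 2 `O=C(Nc1ccc2nc(NC(=O)C3CCCCC3)sc2c1)c1c(Cl)cccc1Cl` gives 0.015 ug/mL in this assay. Compound 3 `O=C(Nc1ccc2nc(NC(=O)C3CCCCC3)sc2c1)c1cccnc1Cl` gives 0.075 ug/mL in this assay.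

Compound 2 stands at the lowest of the two numbers; its nearest neighbour is compound 3, with a 5.0-fold higher number from compound 2 to compound 3 (0.70 log units; beyond the scatter). The other steps, an at least 260-fold lower number from compound 1 to compound 2 (2.42 log units; beyond the scatter) and an at least 53-fold lower number from compound 1 to compound 3 (1.72 log units; beyond the scatter), are large, and all three change only the aryl group on the carbonyl carbon.

Compound 4 `O=C(Nc1ccc2nc(NCC3CCCCC3)sc2c1)c1c(Cl)cccc1Cl` is not yet measured. It differs from compound 2 in this way: cyclohexylmethyl in place of cyclohexylcarbonyl on a nitrogen on an aromatic ring. For the measured compounds named here, none of the measured steps touches the nitrogen on the aromatic ring, so no measured step bears on this change, and the expectation rests on the structural change alone. The number for compound 4 is expected to be higher than that of compound 2, an estimated step of a 10-fold higher number from compound 2 to compound 4 (1.00 log units; beyond the scatter). Compound 4 is therefore estimated at 0.15 ug/mL, within a wide range from 0.015 ug/mL to 2 ug/mL.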

Compound 4, half-maximal effective concentration: 4.3 ug/mL
Estimate against measurement, compound 4: 29-fold (1.46 log units) below; the whole stated range lies below it.
By their numbers in this assay, from the lowest: compound 2; then compound 3; then compound 4.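

For the compounds shown here, the nitrogen on the aromatic ring, which no earlier step touched, proves to be a sensitive place in its own right: in this assay, cyclohexylmethyl in place of cyclohexylcarbonyl gives a 290-fold higher number from compound 2 to compound 4 (2.46 log units; beyond the scatter). The six-membered ring of carbon is present in both groups, so this large step comes from a change that removes the carbonyl and leaves that ring in the molecule. Nothing measured here accounts for the size of this step.

On these data alone, it remains open whether an acetyl or benzoyl group on this nitrogen, or a sulfonyl or urea linkage in place of the amide, would keep the small number of compound 2. As far as these compounds go, it is also open whether cyclohexylmethyl would have a similar effect with 2-chloropyridin-3-yl on the carbonyl carbon.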